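Third Aryl Swap on the Pyrazoline Carbon: Adding a Methoxy

The source may report more compounds than this note shows. Statements on the series, on what has been measured and on what is new or still open speak of the compounds shown alone.

Measured so far, with growth-inhibiting concentration in a functional assay on HOP-92 cells (Homo sapiens) for antiproliferative activity, with a stated time of 48 h; a higher number here means a weaker inhibitor of growth, a lower number a stronger inhibitor of growth:
Compound 1 `Cc1cc(O)c(C2=NN(c3ccc(S(N)(=O)=O)cc3)C(c3ccccc3O)C2)cc1Cl` gives 6510 nM.
Compound 2 `Cc1cc(O)c(C2=NN(c3ccc(S(N)(=O)=O)cc3)C(/C=C/c3ccccc3)C2)cc1Cl` gives 8480 nM.
Compound 3 `COc1ccc(C2CC(c3cc(Cl)c(C)cc3O)=NN2c2ccc(S(N)(=O)=O)cc2)cc1OC` gives 7420 nM.

All three share one core and differ only in the group on a saturated ring carbon. Compound 3 holds the second highest of the three numbers, but its neighbours sit so close that none of them can be separated: the step of a 1.1-fold higher number from compound 1 to compound 3 (0.06 log units; within the scatter) and the step of a 1.1-fold lower number from compound 2 to compound 3 (0.06 log units; within the scatter) both fall inside the scatter, as does a 1.3-fold higher number from compound 1 to compound 2 (0.11 log units; within the scatter). Exchanging a 2-hydroxyphenyl, a 2-phenylethenyl and a 3,4-dimethoxyphenyl at that position left the growth-inhibiting concentration essentially where it was.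

Compound 4 `COc1ccc(C2CC(c3cc(Cl)c(C)cc3O)=NN2c2ccc(S(N)(=O)=O)cc2)c(OC)c1OC` continues this series with a smaller alteration: methoxy in place of hydrogen on an aromatic carbon. For the measured compounds named here, the steps that bear on it are exactly those that reshaped the same aryl group, and every one of them stayed within the scatter. The expectation for compound 4 in this assay is therefore a step of a 1.0-fold higher number from compound 3 to compound 4 (0.00 log units; within the scatter) that does not exceed the scatter in either direction. Compound 4 is expected to give about 7500 nM, with a likely range from 4000 nM to 14000 nM.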

Compound 4, concentration for total growth inhibition: 6990 nM
For compound 4 the middle estimate is 1.1-fold (0.03 log units) above the measured one; the measured number falls inside the stated range.
By their numbers in this assay, from the lowest: compounds 1, 4, 3 and 2 (each within the scatter of the next).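

In this assay, for the compounds shown here, adding one methoxy to the aryl group, ortho to a large group and ortho to a methoxy group, gives a 1.1-fold lower number from compound 3 to compound 4 (0.03 log units; within the scatter) and so moves nothing that can be read; the earlier compounds had swapped whole groups, whereas this shows that a small addition to an aryl group already present is tolerated equally well. The resulting 2,3,4-trimethoxyphenyl also cannot be told apart from the other two groups on the saturated ring carbon, with a 1.2-fold lower number from compound 2 to compound 4 (0.08 log units; within the scatter) when it replaces 2-phenylethenyl and a 1.1-fold higher number from compound 1 to compound 4 (0.03 log units; within the scatter) when it replaces 2-hydroxyphenyl, so all four compounds now sit within the scatter of one another. No measurement at hand offers an explanation for this flat picture.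

Still open, on these data alone, is whether an amine or a carboxylic acid on this aromatic ring, or a longer chain such as butoxy in place of a methoxy, would shift the number beyond the scatter. Also open, as far as these compounds go, is whether changes elsewhere on the shared core would do what these changes on the saturated ring carbon did not.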